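Shortening the linker arm of compound 2 toward compound 4

This account rests on a few compounds, and the source may have more. Where it says the series, first, only, none or still open, it means among the compounds named here.

Of the compounds shown here, three built on one shared core have been tested in a functional assay on MCF7 cells (Homo sapiens) for inhibition, read by MTT assay, with a stated time of 72 h; a higher number here means a weaker inhibitor, a lower number a stronger inhibitor. Compound 1 `COc1cc(NC(C)CCCNC(=O)NNC(=O)Nc2cccc(C(F)(F)F)c2)c2ncccc2c1` gives 190 nM. Compound 2 `COc1cc(NC(C)CCCNC(=O)NNC(=O)Nc2ccc(F)cc2)c2ncccc2c1` gives 310 nM, the highest of the three numbers. Compound 3 `COc1cc(NC(C)CCCNC(=O)NNC(=O)Nc2ccc(C(F)(F)F)cc2)c2ncccc2c1` gives 100 nM. The nearest neighbour of compound 2 is compound 1, a 1.6-fold higher number from compound 1 to compound 2 (0.21 log units; within the scatter), a gap within the scatter; the furthest is compound 3, a 3.1-fold lower number from compound 2 to compound 3 (0.49 log units; beyond the scatter), a modest step beyond the scatter. Between compound 1 and compound 3 the step is a 1.9-fold lower number from compound 1 to compound 3 (0.28 log units; within the scatter), again within the scatter.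

Compound 4 `COc1cc(NC(C)CCCNC(=O)Nc2ccc(Cl)cc2)c2ncccc2c1` differs from compound 2 in one place: 4-chlorophenyl in place of ((4-fluorophenyl)carbamoyl)amino on an amide-type nitrogen. Among the compounds with values here, none of the measured steps alters this part of the molecule; all three exchange one substituted phenyl for another while the longer arm stays in place. They only show that swapping substituents on that outer ring moves the number at most modestly, as in the step from compound 2 to compound 3. Within the data shown here, a change that removes several atoms of the arm has no measured precedent here, so the expectation stays cautious and wide. Compound 4 is expected at 400 nM, between 100 nM and 1600 nM, and the estimated step of a 1.3-fold higher number from compound 2 to compound 4 (0.11 log units; within the scatter) is not expected to exceed the scatter with confidence.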

Compound 4, half-maximal inhibitory concentration: 12000 nM
Compound 4: the middle estimate sits 30-fold (1.48 log units) below what was measured; the measured number lies above the stated range.
By their numbers in this assay, from the lowest: compounds 3, 1 and 2 (each within the scatter of the next, the first and the last beyond it); then compound 4.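

Placing 4-chlorophenyl on the amide-type nitrogen in place of ((4-fluorophenyl)carbamoyl)amino gives, in this assay, a large loss of inhibition (a 39-fold higher number from compound 2 to compound 4 (1.59 log units; beyond the scatter)), far beyond the largest step seen when only the outer ring was changed (a 3.1-fold lower number from compound 2 to compound 3 (0.49 log units; beyond the scatter)). This position therefore tolerates substituent swaps on the outer ring but not this change to the arm, in which 11 heavy atoms with 2 hydrogen-bond donors and 1 hydrogen-bond acceptor leave and 7 heavy atoms with neither enter. No measurement available here accounts for the size of this loss.

The compounds shown leave open which part of this single exchange carries the effect, since the arm's carbamoyl and amino atoms go while chlorine also replaces fluorine on the outer ring. Going by these compounds, it also remains open how the number would respond if a plain carbon chain or a primary amine stood on that same nitrogen, which would show whether the outer phenyl ring or the atoms of the arm matter more.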